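The source may hold more compounds than are shown below. What is called first, only, known or untested is meant among the compounds shown, and "the series" means these compounds.

Measured compounds:
compound 1 `CN(C)CCn1cnnc1-c1cc(Oc2ccc(NC(=O)N/N=C/c3cccc(Br)c3)cc2F)ccn1` — 380 nM
compound 2 `CN(C)CCn1cnnc1-c1cc(Oc2ccc(NC(=O)N/N=C/c3cccc(O)c3)cc2F)ccn1` — 330 nM
compound 3 `CN(C)CCn1cnnc1-c1cc(Oc2ccc(NC(=O)N/N=C/c3ccc(O)c(Br)c3)cc2F)ccn1` — 450 nM

In a functional assay on HT-29 cells (Homo sapiens) for cytotoxicity, read by MTT assay, with a stated time of 72 h (on this read-out lower numbers stand for stronger inhibition and higher numbers for weaker inhibition), compound 1 stands second highest of the three. Its nearest neighbour is compound 2, with a 1.2-fold lower number from compound 1 to compound 2 (0.06 log units; within the scatter); the furthest is compound 3, with a 1.2-fold higher number from compound 1 to compound 3 (0.07 log units; within the scatter). Between those two, a 1.4-fold higher number from compound 2 to compound 3 (0.13 log units; within the scatter). Compound 4 `COc1ccc(/C=N/NC(=O)Nc2ccc(Oc3ccnc(-c4nncn4CCN(C)C)c3)c(F)c2)cc1O` differs from compound 1 in one place: 3-hydroxy-4-methoxyphenyl in place of 3-bromophenyl on a carbon with a double bond to nitrogen. The step from compound 1 to compound 2, also a hydroxy entering in place of bromo, and the two other steps all stayed within the scatter, so in this assay no step beyond the scatter is expected here either. Compound 4 is therefore estimated at 350 nM, with a range from 170 nM to 750 nM, meaning a 1.1-fold lower number from compound 1 to compound 4 (0.04 log units; within the scatter).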

Compound 4, half-maximal inhibitory concentration: 960 nM
Estimate against measurement, compound 4: 2.7-fold (0.44 log units) below; measured number above the stated range.
By their numbers in this assay, from the lowest: compounds 2, 1 and 3 (each within the scatter of the next); then compound 4.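

Compound 4 shows that the aromatic group on a carbon with a double bond to nitrogen can move the number in this assay beyond the scatter (a 2.5-fold higher number from compound 1 to compound 4 (0.40 log units; beyond the scatter); a 2.1-fold higher number from compound 3 to compound 4 (0.33 log units; beyond the scatter)). The clearest case is a single change, an added methoxy group (a 2.9-fold higher number from compound 2 to compound 4 (0.46 log units; beyond the scatter)), which weakens inhibition, unlike the earlier hydroxy and bromo changes. No measurement at hand explains this shift.

As far as these compounds go, whether an ethoxy or an amino group in place of that methoxy would shift the number in the same way stays open.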